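A few compounds are considered here, and "the series" means these few. Any claim that something is new, unique, unknown or untested is made for them only; others in the source may bear on it.

In a functional assay on A549 cells (Homo sapiens) for cytotoxicity, read by WST assay, with a stated time of 48 h (a higher number here means a weaker inhibitor, a lower number a stronger inhibitor), compound 1, whose structure is `Cc1cc2c(c(=O)[nH]1)OC(C(=O)CC(C)C)O2`, gives only a limit of the assay, > 100000 nM. Compound 2, with the structure `CC(C)CC(=O)[C@@H]1O[C@@]12C(=O)C=C(Cc1ccccc1)NC2=O`, likewise reaches only a limit in this assay, > 100000 nM. Compound 3, drawn as `CC1=CC(=O)[C@]2(O[C@@H]2C(=O)CC(C)C)C(=O)N1`, has no number in this assay at all; its entry reads "not determined" (no result reported). So compound 3 stands nowhere on the scale yet, and the only landmark among its neighbours is the limit of > 100000 nM in this assay, at which 2 of the 3 values shown sit.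

Compound 4, with the structure `CC1=CC(=O)C2(OC2C(=O)CC(C)C)C(=O)N1`, is the same molecule as compound 3 drawn without its stereochemistry: the two compounds have the same atoms and bonds; at least one stereo element is drawn with a configuration in one of them and without one in the other: 2 of 2 stereo elements differ; a stereocentre at a saturated ring carbon is drawn S in compound 3 and without a configuration in compound 4; a stereocentre at a saturated ring carbon is drawn S in compound 3 and without a configuration in compound 4. Going by the values given here, no step between measured compounds exists here, and the two measured neighbours sit at a limit, so for this assay the expectation is no step beyond the usual scatter and, most likely, again only a limit rather than a number. The estimate for compound 4 in this assay is 100000 nM, with a range from 30000 nM to 300000 nM.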

Compound 4, half-maximal inhibitory concentration: 32100 nM
Estimate against measurement, compound 4: 3.1-fold (0.49 log units) above; measured number inside the range.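

Compound 4 gives 32100 nM in this assay, but compound 3 offers no number beside it, and no step can be read for this pair. The compounds shown leave open whether the defined configuration drawn in compound 3 changes the result in this assay.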